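The source may hold more compounds than are shown below. What is called first, only, known or untested is meant among the compounds shown, and "the series" means these compounds.

Compounds measured so far:
compound 1 `N#C/C(=C\c1c(F)c(F)c(F)c(F)c1F)C(=O)c1ccc[nH]1` with 31000 nM
compound 2 `N#C/C(=C\c1ccc([N+](=O)[O-])cc1)C(=O)c1c[nH]c2ccccc12` with 47000 nM
compound 3 `COc1ccc(CNC(=O)/C(C#N)=C/c2ccco2)cc1` with 32000 nM

In a functional assay on NCI-H460 cells (Homo sapiens) for inhibition, read by MTT assay, with a stated time of 72 h (a lower number here means a stronger inhibitor of growth, a higher number a weaker inhibitor of growth), compound 3 gives 32000 nM, the second highest of the three numbers. Its nearest neighbour is compound 1, whose 31000 nM lies within the scatter of it, and compound 2, with 47000 nM, is the furthest away, yet still within the scatter. The three compounds therefore cannot be placed in any order of strength; they sit together in a narrow band of weak growth inhibition.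

Compound 4 `COc1ccc(CNC(=O)/C(C#N)=C/c2ccc(Cl)cc2)cc1` has not been measured in this assay. It differs from compound 3 in one place: 4-chlorophenyl in place of furan-2-yl on a double-bonded chain carbon bound to a double-bonded chain carbon. Going by the values given here, no pair of measured compounds shares this change, so nothing in the data tells its direction. Given that compounds 1, 2 and 3 differ widely in their aromatic groups and still fall within the scatter of one another, no step beyond the scatter is expected here, and the estimated step of a 1.1-fold lower number from compound 3 to compound 4 (0.03 log units; within the scatter) is small. Compound 4 is expected to give about 30000 nM, most likely between 8000 nM and 120000 nM.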

Compound 4, concentration for 50% growth inhibition: 14000 nM
Estimate against measurement, compound 4: 2.1-fold (0.33 log units) above; the measured number falls inside the stated range.
By their numbers in this assay, from the lowest: compound 4; then compounds 1, 3 and 2 (each within the scatter of the next).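

In this assay, exchanging the furan-2-yl group for a 4-chlorophenyl group gives a 2.3-fold lower number from compound 3 to compound 4 (0.36 log units; beyond the scatter). Going by these compounds alone, this is the first single change that can be read at all, as the earlier compounds differed from one another in more than one place. It shows that the group at this position can move growth inhibition, if only modestly, with the rest of the molecule held constant, though nothing available explains the step.

As far as these compounds go, it remains open whether the step belongs to the chlorine or to the six-membered ring of carbon, which a plain phenyl group would separate. Also open, from the compounds shown here alone, is how a thiophen-2-yl or a 4-methoxyphenyl group would behave at the same position.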